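Compound 4: Butyl in Place of Sec-Butyl

The compounds below may be only part of what the source reports. "The series", "measured", "known", "first", "only" and "open" are said of these compounds alone.

Measured in an ADME assay on MT4 cells (Homo sapiens) for activation, read by MTT assay; on this read-out higher numbers stand for lower toxicity in this test and lower numbers for higher toxicity in this test:
compound 1 `CCCCSc1nc(C(CC)c2c(F)cccc2Cl)c(C)c(=O)[nH]1`: > 3000 nM (a limit)
compound 2 `CCC(c1nc(SC(C)C)[nH]c(=O)c1C)c1c(F)cccc1F`: > 30000 nM (a limit)
compound 3 `CCC(C)Sc1nc(C(CC)c2c(F)cccc2F)c(C)c(=O)[nH]1`: > 3000 nM (a limit)

None of the three compounds has yet given a number in this assay. Compound 3 is known only as the limit > 3000 nM, which is the limit of > 3000 nM in this assay, at which 2 of the 3 values shown sit. Compound 2 stands instead at the limit of > 30000 nM in this assay, at which 1 of the 3 values shown sits.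

Compound 4 `CCCCSc1nc(C(CC)c2c(F)cccc2F)c(C)c(=O)[nH]1` has butyl in place of sec-butyl on a sulfur. Within the data shown here, the one measured step on this chain is a step that the two limits leave unreadable from compound 2 to compound 3, so it gives no size to carry over. Compound 1 also carries butyl on a sulfur, and it too is known only as the limit > 3000 nM.

Among the measured compounds shown here, no step of definite size or direction is therefore expected in this assay, and the estimate rests mainly on these limits. The expected change is a step that the limit leaves unreadable from compound 3 to compound 4. For compound 4 the estimated value is 30000 nM, with an expected range of 6000 nM to 150000 nM.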

Compound 4, half-maximal cytotoxic concentration: > 3000 nM
Compound 4: no number, only a limit; the forecaster's own chance of this, stated with the estimate: 75%; the middle value lies beyond the limit too.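

In this assay compound 4 gives > 3000 nM, a limit and not a number. Among these compounds, no step from compound 1, compound 2 or compound 3 to compound 4 can be read, as all four are known only as limits. The compounds shown leave open whether changing the chain on sulfur, or fluoro in place of chloro, shifts the half-maximal cytotoxic concentration at all.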